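The source may hold more compounds than are shown below. What is called first, only, known or untested is meant among the compounds shown, and "the series" means these compounds.

Compound 1 `COc1ccccc1/C=C/C(=O)c1c(OC)cc(O)c(CC=C(C)C)c1O`: 14600 nM
Compound 2 `COc1cc(O)cc(O)c1C(=O)/C=C/c1ccc(C)cc1`: > 50000 nM
Compound 3 `COc1cc(OC)c(C(=O)/C=C/c2ccccc2OC)c(OC)c1`: 16300 nM

In a functional assay on HepG2 cells (Homo sapiens) for inhibition, read by MTT assay, with a stated time of 72 h (a higher number here means a weaker inhibitor, a lower number a stronger inhibitor), compound 1 gives 14600 nM and compound 3 gives 16300 nM, two numbers within the usual scatter of each other. Compound 2 gives > 50000 nM, which is a limit of the assay and not a number.

Compound 4 `COc1cc(OC)c(C(=O)/C=C/c2ccc(O)c(O)c2)c(OC)c1` has not yet been measured. It carries 3,4-dihydroxyphenyl in place of 2-methoxyphenyl on a double-bonded chain carbon bound to a double-bonded chain carbon.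

For the measured compounds named here, no pair of measured compounds differs in one place alone, so no step beyond the scatter is expected in this assay. The expectation therefore starts from compound 3 at 16300 nM. The estimated step runs a 1.4-fold lower number from compound 3 to compound 4 (0.13 log units; within the scatter). Compound 4 is expected at about 12000 nM, with an estimated range of 4000 nM to 40000 nM.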

Compound 4, half-maximal inhibitory concentration: 27500 nM
The estimate for compound 4 lay 2.3-fold (0.36 log units) below the measured number, and the stated range covers the measured number.
By their numbers in this assay, from the lowest: compounds 1, 3 and 4 (each within the scatter of the next). At a limit, above all of these: compound 2.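

In this assay putting 3,4-dihydroxyphenyl in place of 2-methoxyphenyl on a double-bonded chain carbon bound to a double-bonded chain carbon gives a 1.7-fold higher number from compound 3 to compound 4 (0.23 log units; within the scatter). For the compounds shown here, this is the first comparison here of two compounds that differ in one place, and it shows that this exchange of rings leaves the number within the scatter. Nothing measured here explains that outcome. Still open, going by these compounds, is whether a different group in the same place, such as a phenyl ring carrying an amine or a carboxylic acid, would shift the number beyond the scatter.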